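The source may hold more compounds than are shown below. What is called first, only, known or untested is meant among the compounds shown, and "the series" means these compounds.

Compound 1 `C=CC(=O)N1CC(Oc2ccc(Oc3c(-c4ccc(F)cc4)sc4cc(O)ccc34)cc2)C1` gives 12300 nM in a functional assay on Ishikawa cells (Homo sapiens) for antiproliferative activity, read by CCK-8 assay, with a stated time of 48 h; a higher number here means a weaker inhibitor, a lower number a stronger inhibitor; compound 2 `C=C(C)C(=O)N1CC(Oc2ccc(Oc3c(-c4ccc(F)cc4)sc4cc(O)ccc34)cc2)C1` gives 14200 nM, and compound 3 `C/C=C/C(=O)N1CC(Oc2ccc(Oc3c(-c4ccc(F)cc4)sc4cc(O)ccc34)cc2)C1` gives 9400 nM, the lowest of the three numbers, although the steps of a 1.3-fold lower number from compound 1 to compound 3 (0.12 log units; within the scatter) and a 1.5-fold lower number from compound 2 to compound 3 (0.18 log units; within the scatter) both lie within the scatter, as does a 1.2-fold higher number from compound 1 to compound 2 (0.06 log units; within the scatter). Compound 4 `O=C(/C=C/CN1CC(Oc2ccc(Oc3c(-c4ccc(F)cc4)sc4cc(O)ccc34)cc2)C1)N1CCC1` differs from compound 3 in that (3-((azetidin-1-yl)carbonyl)prop-2-en-1-yl in place of (prop-1-en-1-yl)carbonyl on an amine nitrogen in a ring). None of the three measured steps resembles this change: each exchanged one small group on the carbonyl carbon and moved the number only within the scatter. There is therefore no direct guide, and the larger change leaves the outcome open. Compound 4 is expected to give about 10000 nM, within 3000 nM to 35000 nM. The step of a 1.1-fold higher number from compound 3 to compound 4 (0.03 log units; within the scatter) that this estimate implies is expected to stay near the scatter.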

Compound 4, half-maximal inhibitory concentration: 5450 nM
Compound 4: middle estimate off by 1.8-fold (0.26 log units), on the high side; low and high end bracket the measured number.
By their numbers in this assay, from the lowest: compounds 4, 3, 1 and 2 (each within the scatter of the next, the first and the last beyond it).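

In this assay, the larger 3-((azetidin-1-yl)carbonyl)prop-2-en-1-yl on an amine nitrogen in a ring is tolerated: a 1.7-fold lower number from compound 3 to compound 4 (0.24 log units; within the scatter) stays within the scatter. Against the other two groups, a 2.3-fold lower number from compound 1 to compound 4 (0.35 log units; beyond the scatter) and a 2.6-fold lower number from compound 2 to compound 4 (0.42 log units; beyond the scatter) are the first steps in this series to pass beyond the scatter, though both are modest. No measurement given here accounts for these steps. The compounds shown leave open how a dimethylamino or piperidin-1-yl group in place of the azetidin-1-yl would read, and whether a longer chain would change the number.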